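The compounds below may be only part of what the source reports. "The series", "measured", "known", "first", "only" and "open" are said of these compounds alone.

Working notes, series around the shared core of compound 1 `CC[C@H](C)[C@H](N)CN(C(=O)[C@@H]1C[C@H]1c1cccc(C#N)c1)c1ccc(-c2ccccc2)cc1`. In a functional assay for agonist activity at G protein-coupled receptor 88 (Homo sapiens), read by HTRF and cAMP accumulation (a higher number here means that more compound is needed for the effect, a lower number that less compound is needed), compound 1 gives 1600 nM, and compound 2 `CC[C@H](C)[C@H](N)CN(C(=O)[C@@H]1C[C@H]1c1ccc(F)cc1F)c1ccc(-c2ccccc2)cc1` gives 1300 nM. Compound 2 holds the lower of the two numbers, with the step of a 1.2-fold lower number from compound 1 to compound 2 (0.09 log units; within the scatter). Compound 3 `CC[C@H](C)[C@H](N)CN(C(=O)[C@@H]1C[C@H]1c1cccnc1)c1ccc(-c2ccccc2)cc1` is the next step; the change is pyridin-3-yl in place of 2,4-difluorophenyl on a saturated ring carbon. Within the data shown here, the one step measured so far, swapping one aromatic ring for another on the same carbon, stayed within the scatter, so no large change is expected here either. Compound 3 is expected at 2500 nM (range 900 nM to 7000 nM). The expected step is a 1.9-fold higher number from compound 2 to compound 3 (0.28 log units; within the scatter).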

Compound 3, half-maximal effective concentration: 1500 nM
Compound 3: middle estimate off by 1.7-fold (0.22 log units), on the high side; low and high end bracket the measured number.
By their numbers in this assay, from the lowest: compounds 2, 3 and 1 (each within the scatter of the next).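

In this assay, pyridin-3-yl on the saturated ring carbon stays level with both carbon-only aromatic rings (a 1.2-fold higher number from compound 2 to compound 3 (0.06 log units; within the scatter); a 1.1-fold lower number from compound 1 to compound 3 (0.03 log units; within the scatter)). The position therefore accepts a six-membered aromatic ring with a hetero atom and a hydrogen-bond acceptor, as well as a ring with fewer heavy atoms, with no step beyond the scatter among compounds 1, 2 and 3. Nothing measured here explains this tolerance.

Going by these compounds, whether any group at this carbon moves the number beyond the scatter stays open. An amine, a carboxylic acid or a saturated cyclohexyl ring would test whether an aromatic ring is needed here at all.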